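Hydrazide series: shortening the aryl ether chain

This account rests on a few compounds, and the source may have more. Where it says the series, first, only, none or still open, it means among the compounds named here.

Measured so far in a functional assay on U-373MG ATCC cells (Homo sapiens) for inhibition, read by MTT assay, with a stated time of 72 h; on this read-out higher numbers stand for weaker inhibition and lower numbers for stronger inhibition:
compound 1 `O=C(NNc1nncc2ccccc12)C1CC1c1ccc(OCC(F)(F)F)cc1` — in this assay compound 1 gives 25000 nM
compound 2 `O=C(NNC(=O)C1CC1c1ccc(OCC(F)(F)F)cc1)c1ccncc1` — in this assay compound 2 gives 19000 nM
compound 3 `CC(C)=CCOc1ccc(C2CC2C(=O)NNC(=O)c2ccncc2)cc1` — for compound 3 this assay reports only a limit, > 100000 nM

Compound 3 stands at the edge of the numbers shown: it carries the limit of > 100000 nM in this assay, at which 1 of the 3 values shown sits, and has no number of its own, so its position relative to compound 1 cannot be ordered, and relative to compound 2 only the direction is known from an at least 5.2-fold higher number from compound 2 to compound 3 (0.72 log units; beyond the scatter).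

The next compound is compound 4 `CCOc1ccc(C2CC2C(=O)NNC(=O)c2ccncc2)cc1`. The change from compound 3 is methyl in place of 2-methylprop-1-en-1-yl on a saturated chain carbon bound to an oxygen on an aromatic ring. For the measured compounds named here, the one measured step at this place is an at least 5.2-fold higher number from compound 2 to compound 3 (0.72 log units; beyond the scatter), where 2-methylprop-1-en-1-yl entered in place of trifluoromethyl and the number rose beyond the scatter. Taking the 2-methylprop-1-en-1-yl out again is expected to bring the number back down, though methyl is not trifluoromethyl, so a return all the way to compound 2 at 19000 nM is not assumed. The expected step is an at least 2.2-fold lower number from compound 3 to compound 4 (0.34 log units; beyond the scatter). For compound 4 the estimate is 45000 nM, with a range from 15000 nM to 130000 nM, and a fair chance that this assay again reports only a limit.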

Compound 4, half-maximal inhibitory concentration: 63000 nM
For compound 4 the middle estimate is 1.4-fold (0.15 log units) below the measured one; the measured number falls inside the stated range.
By their numbers in this assay, from the lowest: compounds 2 and 1 (each within the scatter of the next); then compound 4. At a limit, above all of these: compound 3.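

In this assay, methyl at this place, on a saturated chain carbon bound to an oxygen on an aromatic ring, gives compound 4 a measured number where 2-methylprop-1-en-1-yl gave only a limit, and the change reads as an at least 1.5-fold lower number from compound 3 to compound 4 (0.20 log units; that floor lies within the scatter). The true size of that step stays unfixed, and its floor lies within the scatter, because compound 3 has a limit and no number of its own: the limit of > 100000 nM in this assay, at which 1 of the 4 values shown sits. Methyl and trifluoromethyl can now be compared directly, and a 3.3-fold higher number from compound 2 to compound 4 (0.52 log units; beyond the scatter) shows that the end of this short chain matters even without 2-methylprop-1-en-1-yl.

Still open, on these data alone, is how a longer saturated chain such as propyl would read at this place. An amine or a carboxylic acid at the end of the chain is equally unplaced relative to trifluoromethyl.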